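Cyclopentyl for 3-fluorophenyl on the amide of compound 1

The source may report more compounds than this note shows. Statements on the series, on what has been measured and on what is new or still open speak of the compounds shown alone.

The study compares three measured compounds in an assay on THP-1 cells for displacement of a labelled ligand from C-C chemokine receptor type 1 (Homo sapiens); a lower number here means a stronger inhibitor, a higher number a weaker inhibitor. Compound 1 `CC(C)[C@@H](NC(=O)c1cccc(F)c1)C(=O)N1CCC(c2ccc(Cl)cc2)CC1` gives 24 nM, the lowest of the three numbers. Compound 3 `CC(C)(C)C(NC(=O)c1ccccc1)C(=O)N1CCC(c2ccc(Cl)cc2)CC1` gives 259 nM in this assay, and compound 2 `CC(C)C(NC(=O)OCc1ccccc1)C(=O)N1CCC(c2ccc(Cl)cc2)CC1` gives 1080 nM; both gaps from compound 1 lie beyond the usual scatter, so compound 1 is the strongest inhibitor among those measured.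

The next compound, compound 4 `CC(C)[C@@H](NC(=O)C1CCCC1)C(=O)N1CCC(c2ccc(Cl)cc2)CC1`, differs from compound 1 in a single place: cyclopentyl in place of 3-fluorophenyl on a carbonyl carbon. Going by the values given here, no measured pair shows this exact exchange, so the expectation rests on the surrounding numbers alone. Both measured departures from compound 1, in compound 3 and compound 2, weaken binding in this assay, and an aromatic ring is kept in every measured compound. Compound 4 is therefore expected to be a weaker inhibitor than compound 1, with an estimated step of a 6.3-fold higher number from compound 1 to compound 4 (0.80 log units; beyond the scatter) that is moderate and beyond the scatter. Compound 4 is estimated at 150 nM in this assay, within a range from 40 nM to 600 nM.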

Compound 4, half-maximal inhibitory concentration: 70 nM
Compound 4: middle estimate off by 2.1-fold (0.33 log units), on the high side; the measured number falls inside the stated range.
By their numbers in this assay, from the lowest: compound 1; then compound 4; then compound 3; then compound 2.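

Going by these compounds alone, compounds 2 and 3 each differ from compound 1 in more than one place, so this is the first single change read at this position. In this assay, exchanging 3-fluorophenyl for cyclopentyl on the carbonyl carbon gives a modest loss (a 2.9-fold higher number from compound 1 to compound 4 (0.46 log units; beyond the scatter)), and compound 4 still gives 70 nM, so among these two compounds an aromatic ring at this position is not essential for a number of this order. Nothing measured here explains the size of this step.

The exchange changes the ring size, removes aromatic character and removes fluorine together, so the share of each remains unresolved. From the compounds shown here alone, it also remains open how a cyclohexyl ring, a piperidine ring or an open butyl chain on this carbonyl carbon would compare with cyclopentyl.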